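Sulfonyl substituent and stability of a triazine amide series

The compounds below may be only part of what the source reports. "The series", "measured", "known", "first", "only" and "open" are said of these compounds alone.

Measured so far:
compound 1 `O=C(NS(=O)(=O)c1ccc(F)cc1)c1ccc(Nc2nc(NC3(c4ccc(Cl)cc4)CC3)nc(OCC(F)(F)F)n2)cc1`: 99%
compound 2 `O=C(NS(=O)(=O)CCNC(=O)C1CC1)c1ccc(Nc2nc(NC3(c4ccc(Cl)cc4)CC3)nc(OCC(F)(F)F)n2)cc1`: "not active" (no number reported)

In an ADME assay on microsomes from liver (Rattus norvegicus) for metabolic stability, with a stated time of 10 min (on this read-out higher numbers stand for a more stable compound and lower numbers for a less stable compound), compound 1 gives 99%. Compound 2 is reported in this assay only as "not active" (no number reported), with no single number, so its position on the scale is not fixed. Compound 3 `O=C(NS(=O)(=O)c1ccccc1)c1ccc(Nc2nc(NC3(c4ccc(Cl)cc4)CC3)nc(OCC(F)(F)F)n2)cc1` differs from compound 2 by phenyl in place of 2-((cyclopropylcarbonyl)amino)ethyl on a sulfonyl sulfur. Going by the values given here, no measured step covers this change, so its size is uncertain; the only measured neighbour, compound 1, which carries a closely related group and gives 99%, points towards a high value rather than a low one. Compound 3 is therefore expected to give about 95% in this assay, within a range from 80% to 100%.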

Compound 3, percent of the compound remaining: 100%
For compound 3 the middle estimate is 5 percentage points below the measured one; the measured number falls inside the stated range.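

In this assay, hydrogen in place of fluoro on an aromatic carbon gives a number 1 percentage points higher from compound 1 to compound 3 (within the scatter), so the fluoro makes no readable difference on this aromatic group. The change from 2-((cyclopropylcarbonyl)amino)ethyl to phenyl on the sulfonyl sulfur cannot be read, since compound 2 has no single number. No measured evidence bears on this result. Still open, as far as these compounds go, is where a plain methyl on the sulfonyl sulfur, or a phenyl carrying a carboxylic acid or an amine, would fall on this scale.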